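This account rests on a few compounds, and the source may have more. Where it says the series, first, only, none or still open, it means among the compounds named here.

Compound 1 `Cc1nc(N)sc1CCCN/C(N)=N/C(=O)N[C@H](C)c1ccccc1`: 7.59 nM; compound 2 `Cc1nc(N)sc1CCCN/C(N)=N/C(=O)NC(C)c1ccc(Br)cc1`: 55 nM; compound 3 `Cc1nc(N)sc1CCCN/C(N)=N/C(=O)NC(c1ccccc1)C(C)C`: 34.7 nM.

All three were tested in a functional assay on Right cardiac atrium for agonist activity at histamine H2 receptor (Cavia porcellus), with a stated time of 30 min, in the presence of a further agent that is not named here; on this read-out lower numbers stand for an effect already at smaller amounts and higher numbers for an effect only at larger amounts of compound. Compound 1 has the lowest of the three numbers; compound 3 and compound 2 both lie beyond the usual scatter from it, so compound 1 is the most potent of the measured set. Compound 4 `Cc1nc(N)sc1CCCN/C(N)=N/C(=O)NCc1ccco1` has not yet been measured. It differs from compound 1 in one place: (furan-2-yl)methyl in place of 1-phenylethyl on an amide-type nitrogen. The two measured compounds that carry other groups on the same nitrogen both give higher numbers than compound 1, so the expectation for compound 4 is a moderate step upward, a 4.0-fold higher number from compound 1 to compound 4 (0.60 log units; beyond the scatter). Compound 4 is therefore estimated at 30 nM, with a likely range from 8 nM to 120 nM.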

Compound 4, half-maximal effective concentration: 11.8 nM
Compound 4: middle estimate off by 2.5-fold (0.41 log units), on the high side; measured number inside the range.
By their numbers in this assay, from the lowest: compounds 1 and 4 (each within the scatter of the next); then compounds 3 and 2 (each within the scatter of the next).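

In this assay, the move to (furan-2-yl)methyl gives a 1.6-fold higher number from compound 1 to compound 4 (0.19 log units; within the scatter). This shows that the group on this amide-type nitrogen need not hold a six-membered aromatic ring of carbon only, nor a defined stereocentre, to stay within the scatter of 1-phenylethyl. No measurement here accounts for this. From the compounds shown here alone, the ring and the stereocentre change together in this step, so their separate contributions remain unknown. Going by these compounds, a benzyl group or an open butyl chain on this nitrogen remains open.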